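This account rests on a few compounds, and the source may have more. Where it says the series, first, only, none or still open, it means among the compounds named here.

Compound 1 `CCCc1cc2ccccc2nc1-c1cc(-c2ccc(F)cc2)no1` carries a propyl chain on the shared core. In a functional assay on PC-3 cells (Homo sapiens) for inhibition, read by MTT assay, with a stated time of 24 h (on this read-out higher numbers stand for weaker inhibition and lower numbers for stronger inhibition), compound 1 gives 42200 nM. Compound 2 `CCCCc1cc2ccccc2nc1-c1cc(-c2ccc(F)cc2)no1` differs from it by methyl in place of hydrogen on a saturated chain carbon, three bonds along the chain from an aromatic carbon, and in this assay compound 2 gives 26300 nM; the step is a 1.6-fold lower number from compound 1 to compound 2 (0.21 log units; within the scatter). Compound 3 `CCCCc1cc2ccccc2nc1-c1cc(-c2ccc(C)cc2)no1` carries a methyl group in place of the fluoro on the aromatic ring. In this assay compound 3 reaches only the assay limit of > 100000 nM, a limit and not a number, and the step is an at least 3.8-fold higher number from compound 2 to compound 3 (0.58 log units; beyond the scatter). The difference between the core of compound 1 and the core of compound 3 is not broken down here.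

Compound 4 `CCCCCc1cc2ccccc2nc1-c1cc(-c2ccc(C)cc2)no1` has not been measured. It differs from compound 3 by methyl in place of hydrogen on a saturated chain carbon, four bonds along the chain from an aromatic carbon, the same kind of change as from compound 1 to compound 2, but here the place is four bonds along the chain from an aromatic carbon rather than three. Because compound 3 already sits at the limit of > 100000 nM in this assay, at which 1 of the 3 values shown sits, and the earlier step from compound 1 to compound 2 a 1.6-fold lower number from compound 1 to compound 2 (0.21 log units; within the scatter) was small, compound 4 is expected to give about 100000 nM, a step of a number no higher from compound 3 to compound 4 (the limit leaves the size open), most likely again as a limit.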

Compound 4, half-maximal inhibitory concentration: > 100000 nM
Compound 4: no number, only a limit (the forecaster's own chance of this, stated with the estimate: 65%); the middle value sits exactly at the limit.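

No step can be read between compound 3 and compound 4 in this assay, because both give only a limit and not a number: the limit of > 100000 nM in this assay, at which 2 of the 4 values shown sit.

The compounds shown leave open how strongly compound 3 and compound 4 actually inhibit, and whether methyl in place of hydrogen at this place on the chain changes anything when the aromatic ring carries methyl instead of fluoro.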